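The source may report more compounds than this note shows. Statements on the series, on what has been measured and on what is new or still open speak of the compounds shown alone.

In a functional assay on A-375 cells (Homo sapiens) for antiproliferative activity, read by MTT assay, with a stated time of 24 h, tested at 11.11 ug/mL (on this read-out lower numbers stand for a weaker effect and higher numbers for a stronger effect at the one concentration tested), three compounds built on a shared core have been measured. Compound 1 `Cc1ccc2nc(C(=O)Nc3c(F)cc(-c4cccc(F)c4)cc3F)c(C)c(O)c2c1` gives 17.9%. Compound 2 `CCc1ccc2nc(C(=O)Nc3c(F)cc(-c4cccc(F)c4)cc3F)c(C)c(O)c2c1` gives 26.4%. Compound 3 `Cc1c(C(=O)Nc2c(F)cc(-c3cccc(F)c3)cc2F)nc2ccc(OC(F)(F)F)cc2c1O` gives 11.3%, the lowest of the three numbers, although its gap to compound 1 lies within the scatter and only its gap to compound 2 lies beyond it.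

Compound 4 `Cc1c(C(=O)Nc2c(F)cc(-c3cccc(F)c3)cc2F)nc2ccc(C(F)(F)F)cc2c1O` differs from compound 3 at a single place: trifluoromethyl in place of trifluoromethoxy on an aromatic carbon. Among the compounds with values here, no measured step swaps trifluoromethyl for trifluoromethoxy. The two steps that touch the same aromatic carbon both put trifluoromethoxy in place of an alkyl group: a number 6.6 percentage points lower from compound 1 to compound 3 (within the scatter), while a number 15.1 percentage points lower from compound 2 to compound 3 (beyond the scatter). Neither says how trifluoromethyl compares with trifluoromethoxy, so no step beyond the scatter is expected in either direction. The expected step is a number 3.7 percentage points higher from compound 3 to compound 4 (within the scatter). Compound 4 is therefore estimated to give 15%, with a likely range from 5% to 30%.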

Compound 4, a percentage reported as inhibition, at one concentration (the size of the read-out at that concentration, not a potency): 46.3%
Estimate against measurement, compound 4: 31.3 percentage points below; measured number outside the range, above it.
By their numbers in this assay, from the lowest: compounds 3, 1 and 2 (each within the scatter of the next, the first and the last beyond it); then compound 4.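

On this aromatic carbon, trifluoromethyl stands clear of all three other groups shown: trifluoromethoxy (a number 35 percentage points higher from compound 3 to compound 4 (beyond the scatter)), ethyl (a number 19.9 percentage points higher from compound 2 to compound 4 (beyond the scatter)) and methyl (a number 28.4 percentage points higher from compound 1 to compound 4 (beyond the scatter)). Trifluoromethoxy and trifluoromethyl differ by a single oxygen atom, yet this step is the only one rated large, so the earlier pairs gave no hint that so small an edit at this position could shift the read-out this far. Nothing available explains the gap.

As far as these compounds go, with four groups at one position, it remains open whether the higher number belongs to trifluoromethyl alone or would also appear with a group such as chlorine, a nitrile or an amine. Each compound also has a reading at a single concentration, so the numbers show only a stronger or weaker effect at that concentration and nothing beyond it.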